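Methyl on the hydroxy oxygen of compound 2

The source may hold more compounds than are shown below. What is called first, only, known or untested is meant among the compounds shown, and "the series" means these compounds.

Measured in an ADME assay on S9 fraction from liver (Rattus norvegicus) for metabolic stability, with a stated time of 60 min; a higher number here means that more of the compound is left, a lower number that less of the compound is left:
compound 1 `CO[C@H]1CC[C@H](CN2C(=O)CNc3ncc(-c4ccc(-c5nc[nH]n5)nc4C)nc32)CC1`: 100%
compound 2 `Cc1nc(-c2nc[nH]n2)ccc1-c1cnc2c(n1)N([C@H]1CC[C@H](O)CC1)C(=O)CN2`: 91%

For the measured compounds named here, compound 2, at 91%, stands within the scatter of compound 1, the only other measured compound. The step between them is a number 9 percentage points lower from compound 1 to compound 2 (within the scatter), so no order can be read from the pair.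

Next in the series is compound 3 `CO[C@H]1CC[C@H](N2C(=O)CNc3ncc(-c4ccc(-c5nc[nH]n5)nc4C)nc32)CC1`, defined by methyl in place of hydrogen on an oxygen on a saturated carbon. This is methyl in place of hydrogen on an oxygen on a saturated carbon, or hydroxy to methoxy, which turns 4-hydroxycyclohexyl into 4-methoxycyclohexyl.

Going by the values given here, only one measured step bears on this change, and only indirectly: a number 9 percentage points lower from compound 1 to compound 2 (within the scatter) also replaces (4-methoxycyclohexyl)methyl, so it does not isolate the methyl. Among the compounds with values here, no measured pair does. Within the data shown here, still, compound 1 carries a methoxy group and gives 100% in this assay, and the one step available is small. No step beyond the scatter is therefore expected in this assay, in either direction.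

The expected step is a number 3 percentage points higher from compound 2 to compound 3 (within the scatter), an estimate only. Compound 3 is estimated at 94%, with an expected range from 82% to 100%.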

Compound 3, percent of the compound remaining: 72%
Compound 3: the middle estimate sits 22 percentage points above what was measured; the measured number lies below the stated range.
By their numbers in this assay, from the lowest: compound 3; then compounds 2 and 1 (each within the scatter of the next).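

In this assay, for the compounds shown here, this is the first step that lies beyond the scatter: a number 19 percentage points lower from compound 2 to compound 3 (beyond the scatter), so methyl in place of hydrogen on this oxygen on a saturated carbon does register at this position, and the methoxy form is the lower of the two. A methoxy group alone does not fix the number, since compound 1 also carries one and the attachment to the amide-type nitrogen in a ring also counts: a number 28 percentage points lower from compound 1 to compound 3 (beyond the scatter), with 4-methoxycyclohexyl in place of (4-methoxycyclohexyl)methyl. Nothing at hand accounts for either step.

On these data alone, whether the step belongs to methyl in particular stays open, as does the question of whether ethoxy, an amine or a carboxylic acid in place of the hydroxy would read with compound 2 or with compound 3. Also open, as far as these compounds go, is how (4-hydroxycyclohexyl)methyl on the same nitrogen would read in this assay, which would show whether the hydroxy to methoxy step holds when the cyclohexyl ring is attached through methyl.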